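The source may report more compounds than this note shows. Statements on the series, on what has been measured and on what is new or still open speak of the compounds shown alone.

Working notes on the series. In a functional assay on CLL cells (Homo sapiens) for cytotoxicity, read by MTT assay, with a stated time of 48 h (a lower number here means that less compound is needed, a higher number that more compound is needed for the effect), compound 1 (`C=C(CC)C(=O)c1ccc(OCC(=O)Nc2nc3ccccc3s2)c(Cl)c1Cl`) gives 1500 nM and compound 2 (`C=C(CC)C(=O)c1ccc(OCC(=O)Nc2ccc(/C=C/C(=O)NO)cc2)c(Cl)c1Cl`) gives 2600 nM as its reading. These two numbers lie within the usual scatter of each other, so compound 2 stands level with compound 1 and no order can be drawn between them.

Compound 3 (`C=C(CC)C(=O)c1ccc(OCC(=O)Nc2ccc(CC(=O)O)cc2)c(Cl)c1Cl`) has no reading yet. It departs from compound 2 on an aromatic carbon of a six-membered aromatic ring of carbon only, para to a large group, with carboxymethyl in place of 2-(hydroxycarbamoyl)ethenyl (carboxymethyl in place of 2-(hydroxycarbamoyl)ethenyl on an aromatic carbon).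

Within the data shown here, the series holds no measured step between closely matched compounds, so nothing sizes this change directly and the expectation remains a judgement with a wide range. A moderate move in this assay towards a higher number, beyond the scatter, is expected. The estimated change is a 2.7-fold higher number from compound 2 to compound 3 (0.43 log units; beyond the scatter) in this direction. Compound 3 is estimated at 7000 nM with 2500 nM to 20000 nM as the expected range.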

Compound 3, half-maximal effective concentration: 3200 nM
Beside the measured number, compound 3's estimate is 2.2-fold (0.34 log units) above it, and the stated range covers the measured number.
By their numbers in this assay, from the lowest: compounds 1, 2 and 3 (each within the scatter of the next, the first and the last beyond it).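

Among these compounds, this is the first sized step at this position, an aromatic carbon para to a large group. In this assay, carboxymethyl in place of 2-(hydroxycarbamoyl)ethenyl gives a 1.2-fold higher number from compound 2 to compound 3 (0.09 log units; within the scatter), so compounds 2 and 3 stand level even though the entering group has fewer heavy atoms, one double bond outside aromatic rings instead of two, and one hydrogen-bond donor and acceptor instead of two of each. The reading at this position therefore does not depend on keeping the 2-(hydroxycarbamoyl)ethenyl group intact, at least for this one replacement, and no measurement on hand accounts for this result.

One swap cannot show whether the position tolerates change in general, since both groups carry a chain ending in a hydrogen-bond donor and acceptor. Still open, from the compounds shown here alone, is whether an amine such as aminomethyl, a longer chain such as 3-carboxypropyl, or a plain methyl at this aromatic carbon would also stand level with compound 2 or move the reading beyond the scatter.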